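Swapping an Ester Tail on Two Furan Isomers

The source may report more compounds than this note shows. Statements on the series, on what has been measured and on what is new or still open speak of the compounds shown alone.

Compound 1 `CC1=C(C(=O)OCC(C)C)C(c2ccco2)NC(=S)N1` carries an isobutyl ester and a furan-2-yl group on a shared core. In an assay on membranes from CHO cells for displacement of a labelled ligand from adenosine receptor A1 (Homo sapiens), read by scintillation counting, with a stated time of 60 min, tested at 1 uM (a lower number here means less inhibition, a higher number more inhibition at the concentration tested (going by the name of the read-out)), compound 1 gives 7%. Compound 2 `CC1=C(C(=O)OC(C)(C)C)C(c2ccco2)NC(=S)N1` differs from it in one place: tert-butyl in place of isobutyl on an oxygen next to a carbonyl group. In this assay compound 2 gives 3%, so the step of a number 4 percentage points lower from compound 1 to compound 2 (within the scatter) stays small. Compound 3 `CC1=C(C(=O)OCC(C)C)C(c2ccoc2)NC(=S)N1` keeps the isobutyl ester of compound 1 and differs from it only in how the furan is attached: furan-3-yl in place of furan-2-yl on a saturated ring carbon. In this assay compound 3 gives 12%, and the step of a number 5 percentage points higher from compound 1 to compound 3 (within the scatter) also does not rise out of the scatter. All three measured compounds show little inhibition at the concentration tested, and none of them can be told apart from the others on these numbers.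

Compound 4 `CC1=C(C(=O)OC(C)(C)C)C(c2ccoc2)NC(=S)N1` has not yet been measured. It relates to compound 3 as compound 2 relates to compound 1: tert-butyl in place of isobutyl on an oxygen next to a carbonyl group. The place of this change is described in the same words for both pairs, so it is the same change, now made a second time on the core of compound 3. For compound 4 the step of a number 4 percentage points lower from compound 3 to compound 4 (within the scatter) is expected, because the same change gave a number 4 percentage points lower from compound 1 to compound 2 (within the scatter) on the other core. Compound 4 is therefore estimated at 8%, with a likely range from 0% to 18%.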

Compound 4, a percentage reported as inhibition, at one concentration (the size of the read-out at that concentration, not a potency): 18%
Compound 4: middle estimate off by 10 percentage points, on the low side; the range from low to high includes it.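

The ester change, tert-butyl in place of isobutyl, gives a number 6 percentage points higher from compound 3 to compound 4 (within the scatter) in this assay, and set beside its first appearance it shows no difference between the two cores that rises above the noise: the same change on two cores in this assay, a number 4 percentage points lower (within the scatter) from compound 1 to compound 2 and a number 6 percentage points higher (within the scatter) from compound 3 to compound 4, 10 percentage points apart, within the scatter of two such steps. The furan change, furan-3-yl in place of furan-2-yl, gives a number 15 percentage points higher from compound 2 to compound 4 (beyond the scatter), the only step among these four compounds that is beyond the scatter, yet it too cannot be told apart from its earlier counterpart: the same change on two cores in this assay, a number 5 percentage points higher (within the scatter) from compound 1 to compound 3 and a number 15 percentage points higher (beyond the scatter) from compound 2 to compound 4, 10 percentage points apart, within the scatter of two such steps. Neither change is shown to behave differently from one core to the other, but this does not prove that either one carries over exactly, as all four readings are low and each comes from a single concentration, which gives no potency.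

The compounds shown leave open how this assay would respond to a longer chain on the oxygen that carries the tert-butyl or isobutyl group, or to an amine on the saturated ring carbon that holds the furan. Also open, from the compounds shown here alone, is how far any of the four compounds would inhibit at other concentrations.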